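Aryl ether replacing aryl thioether in the quinoxaline-type series

The compounds below may be only part of what the source reports. "The series", "measured", "known", "first", "only" and "open" are said of these compounds alone.

Measured compounds:
compound 1 `CCOC(=O)[C@H](CCC(=O)O)NC(=O)c1ccc(Sc2nc3cc(N)cc(N)c3nc2-c2ccccc2)cc1` — 11200 nM
compound 2 `COc1cc(CNc2nc3cc(N)cc(N)c3nc2-c2ccccc2)cc(OC)c1OC` — 229 nM
compound 3 `COc1ccc(Sc2nc3cc(N)cc(N)c3nc2-c2ccccc2)cc1` — < 100000 nM

In a functional assay on MDA-MB-435 cells (Homo sapiens) for inhibition, read by sulforhodamine B assay, with a stated time of 48 h (on this read-out higher numbers stand for weaker inhibition of growth and lower numbers for stronger inhibition of growth), compound 1 gives 11200 nM and compound 2 gives 229 nM. For compound 3 the number recorded in this assay is only a limit, < 100000 nM, so where it stands among the three is not fixed by a value; it is the one case of the limit of < 100000 nM in this assay, at which 1 of the 3 values shown sits, in the set. Within the data shown here, no step between two measured compounds differing in a single place is available.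

Compound 4 `Nc1cc(N)c2nc(-c3ccccc3)c(Oc3ccc(F)cc3)nc2c1` is not yet measured. It differs from compound 3 by 4-fluorophenoxy in place of (4-methoxyphenyl)sulfanyl on an aromatic carbon, in words a 4-fluorophenoxy in place of a (4-methoxyphenyl)sulfanyl on an aromatic carbon. Since compound 3 carries only a limit, the step cannot be sized from data. Compound 2, carrying a trimethoxybenzylamino group on the same position of the shared core, sits at 229 nM, whereas the thioether compound 1 sits at 11200 nM; compound 4 is expected somewhere between these, nearer the weaker end. Compound 4 is therefore estimated at 20000 nM (range 2000 nM to 100000 nM), a step that the limit leaves unreadable from compound 3 to compound 4 in direction toward stronger inhibition, with a real chance that the assay again reports only a limit.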

Compound 4, concentration for 50% growth inhibition: 15800 nM
The estimate for compound 4 lay 1.3-fold (0.10 log units) above the measured number; low and high end bracket the measured number.
By their numbers in this assay, from the lowest: compound 2; then compounds 1 and 4 (each within the scatter of the next).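

No step can be read from compound 3 to compound 4, since compound 3 carries only a limit: the limit of < 100000 nM in this assay, at which 1 of the 4 values shown sits. The compounds shown leave open how 4-fluorophenoxy compares in size of effect with (4-methoxyphenyl)sulfanyl on the shared core.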